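Swapping a Benzyl for an Aryl Ether on the Shared Core

The compounds below may be only part of what the source reports. "The series", "measured", "known", "first", "only" and "open" are said of these compounds alone.

Compound 1 `COc1ccc(F)cc1CNCCCNc1ccnc2cc(Cc3cc(C)cc(C)c3)ccc12`: 23 10^-6 cm/s
Compound 2 `Cc1cc(C)cc(Cc2ccc3c(NCCCNCc4ccco4)ccnc3c2)c1`: 23 10^-6 cm/s
Compound 3 `COc1cccc(CNCCCNc2ccnc3cc(Oc4cccc(N(C)C)c4)ccc23)c1O`: 317 10^-6 cm/s

In an ADME assay for permeability, using PAMPA, with a stated time of 30 min, at pH 7.4 (a higher number here means that the compound crosses the layer faster, a lower number that the compound crosses the layer more slowly), compound 1 gives 23 10^-6 cm/s. That places compound 1 level with compound 2 at the digits shown, the two together being the lowest of the three numbers, while compound 3 sits far higher, its value of 317 10^-6 cm/s being a difference beyond the scatter.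

Compound 4 `COc1ccc(F)cc1CNCCCNc1ccnc2cc(Oc3ccc(F)cc3)ccc12` is the next compound to be measured in this assay. It differs from compound 1 in one place: 4-fluorophenoxy in place of 3,5-dimethylbenzyl on an aromatic carbon.

Going by the values given here, the single measured step, no change at the digits printed from compound 1 to compound 2 (within the scatter), touches a different part of the molecule and says nothing about this position. Compound 3 carries an aryl ether on the core, as compound 4 will, but it differs from compound 1 in more than one place, so only its two values can be set side by side. The account therefore expects a step upward from compound 1, of uncertain size, with a 2.6-fold higher number from compound 1 to compound 4 (0.42 log units; beyond the scatter) as the estimated change. For compound 4 the expected permeability in this assay is 60 10^-6 cm/s, within a range from 20 10^-6 cm/s to 200 10^-6 cm/s.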

Compound 4, apparent permeability: 317 10^-6 cm/s
For compound 4 the middle estimate is 5.3-fold (0.72 log units) below the measured one; the whole stated range lies below it.
By their numbers in this assay, from the lowest: compounds 1 and 2 (each within the scatter of the next); then compounds 3 and 4 (each within the scatter of the next).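

In this assay, replacing 3,5-dimethylbenzyl with 4-fluorophenoxy on this aromatic carbon of the shared core gives a 14-fold higher number from compound 1 to compound 4 (1.14 log units; beyond the scatter) as a large step, with the 5-fluoro-2-methoxyphenyl group unchanged. The only step shown earlier lay in a different part of the molecule and stayed within the scatter, so this is the first single change shown to move the read-out beyond it. Nothing measured here bears on the reason for this step.

The swap changes the group's link to the core and its ring substituents together, so 3,5-dimethylphenoxy and 4-fluorobenzyl at this position would be needed to tell those two changes apart. Going by these compounds, it also remains open whether a step of this size would recur with furan-2-yl in place of 5-fluoro-2-methoxyphenyl.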